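Phenyl for chloro in a pyrimidine thioether series

The source may report more compounds than this note shows. Statements on the series, on what has been measured and on what is new or still open speak of the compounds shown alone.

Measured compounds:
compound 1 `CC(=O)c1ccc(Nc2ccnc(SCC(=O)c3ccc(Br)cc3)n2)cc1` 24%
compound 2 `CC(=O)c1cccc(Nc2ccnc(SCC(=O)c3ccc(-c4ccccc4)cc3)n2)c1` 23%
compound 3 `CC(=O)c1ccc(Nc2ccnc(SCC(=O)c3ccc(Cl)cc3)n2)cc1` 21%

All three were tested in a functional assay on CAKI-1 cells (Homo sapiens) for inhibition, read by sulforhodamine B assay, with a stated time of 48 h, tested at 10 uM; on this read-out lower numbers stand for less inhibition of growth and higher numbers for more inhibition of growth at the one concentration tested. Compound 3 stands lowest of the three numbers, but its neighbours lie close: compound 2 is nearest and compound 1 furthest, and both differences are within the scatter, so no order among them can be claimed.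

For the measured compounds named here, the only single-point step among the measured compounds is the one from compound 1 to compound 3, a number 3 percentage points lower from compound 1 to compound 3 (within the scatter), a change that did nothing beyond the scatter.

Compound 4 `CC(=O)c1ccc(Nc2ccnc(SCC(=O)c3ccc(-c4ccccc4)cc3)n2)cc1` is not yet measured. It differs from compound 3 by phenyl in place of chloro on an aromatic carbon. Going by the values given here, no measured pair covers this exact exchange. What bears on it is indirect: the bromo-to-chloro step left the number unchanged, and compound 2, which carries a phenyl at this place on a differently arranged core, gives a number close to compound 3. On that basis compound 4 is expected to show a step of a number 2 percentage points higher from compound 3 to compound 4 (within the scatter), that is, no change beyond the scatter. The estimated value for compound 4 is 23%, with an expected range from 12% to 35%.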

Compound 4, percent growth inhibition at one concentration: 16%
For compound 4 the middle estimate is 7 percentage points above the measured one; low and high end bracket the measured number.
By their numbers in this assay, from the lowest: compounds 4, 3, 2 and 1 (each within the scatter of the next).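

In this assay, phenyl in place of chloro on an aromatic carbon gives a number 5 percentage points lower from compound 3 to compound 4 (within the scatter), and phenyl in place of bromo gives a number 8 percentage points lower from compound 1 to compound 4 (within the scatter). With the shared core held constant, this place, para to a large group, therefore takes six heavy atoms and a whole aromatic ring instead of a single halogen with no change beyond the scatter, which the step between the two halogens alone could not show. The result also adds a comparison of the acetyl placement: 4-acetylphenyl in place of 3-acetylphenyl on a nitrogen gives a number 7 percentage points lower from compound 2 to compound 4 (within the scatter), again within the scatter, while no measurement of any other property of these compounds is at hand to bear on these numbers.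

From the compounds shown here alone, what remains open is whether anything at this place can move the number beyond the scatter, for example an amine, a carboxylic acid or a longer chain in place of the phenyl. The four compounds also leave open how they would compare at any other concentration or in other cell lines, since this assay reports one concentration on one line.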